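Chloro added to the fused core of compound 2

The source may hold more compounds than are shown below. What is called first, only, known or untested is meant among the compounds shown, and "the series" means these compounds.

Measured in a functional assay on NCI-H226 cells (Homo sapiens) for cytotoxicity, read by sulforhodamine B assay, with a stated time of 48 h; a higher number here means a weaker inhibitor of growth, a lower number a stronger inhibitor of growth:
compound 1 `ClCc1ccccc1Cn1cnc2c(Cl)ncnc21` gives 12600 nM
compound 2 `ClCc1cccc(Cn2cnc3c(Cl)ncnc32)c1` gives 14400 nM
compound 3 `ClCc1ccc(Cn2cnc3nc(Cl)nc(Cl)c32)cc1` gives 3890 nM

Compound 2 has the highest of the three numbers. Compound 1 lies within the scatter of compound 2; compound 3 lies beyond it, with the lower number. Compound 4 `ClCc1cccc(Cn2cnc3c(Cl)nc(Cl)nc32)c1` differs from compound 2 by chloro in place of hydrogen on an aromatic carbon, the new chloro sitting between two ring nitrogen atoms of the fused core. Going by the values given here, no pair of measured compounds isolates this change; compound 3 carries chloro at the same place on its core but also differs from compound 2 in where the chloromethyl sits on the benzyl ring, so its value gives only a rough pointer. A downward step beyond the scatter is expected, a 2.9-fold lower number from compound 2 to compound 4 (0.46 log units; beyond the scatter). Compound 4 is therefore estimated at 5000 nM, with a range from 2000 nM to 12000 nM.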

Compound 4, concentration for total growth inhibition: 10000 nM
For compound 4 the middle estimate is 2.0-fold (0.30 log units) below the measured one, within the range that was stated.
By their numbers in this assay, from the lowest: compound 3; then compounds 4, 1 and 2 (each within the scatter of the next).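

In this assay the chloro in place of hydrogen on an aromatic carbon, between two ring nitrogen atoms, gives a 1.4-fold lower number from compound 2 to compound 4 (0.16 log units; within the scatter) and so stays within the scatter. Going by these compounds alone, this is the first reading of the change on its own, and at this position on the core of compound 2 the chloro is tolerated without a change that can be told from the scatter. No supporting data bear on this result.

Still open, on these data alone, is how an amine, a methoxy group or a longer chain would behave at this position. Also open, as far as these compounds go, is whether the chloro gives a similar step on the core of compound 1.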